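Compound 4: an Ethyl for a Methyl, Little Change Expected

The compounds below may be only part of what the source reports. "The series", "measured", "known", "first", "only" and "open" are said of these compounds alone.

Three compounds carrying the same core were tested in a functional assay on MCF7 cells (Homo sapiens) for cytotoxicity, read by MTT assay, with a stated time of 24 h, tested at 6.4 ug/mL; a higher number here means a stronger effect of the compound at the concentration tested, a lower number a weaker effect. Compound 1 `Cn1c(-c2ccc(NC(=O)CSc3nc4cc(Cl)ccc4o3)cc2)nc(-c2ccccc2)c1-c1ccccc1` gives 27.7%, compound 2 `Cc1ccc2oc(SCC(=O)Nc3ccc(-c4nc(-c5ccccc5)c(-c5ccccc5)n4C)cc3)nc2c1` gives 24.6%, and compound 3 `CN1CCN(CC(=O)Nc2ccc(-c3nc(-c4ccccc4)c(-c4ccccc4)n3C)cc2)CC1` gives 28.6%. Every step among them is small: a number 3.1 percentage points lower from compound 1 to compound 2 (within the scatter), a number 0.9 percentage points higher from compound 1 to compound 3 (within the scatter), and a number 4 percentage points higher from compound 2 to compound 3 (within the scatter). Compound 3 therefore stands within the scatter of both compound 1 and compound 2, and no one of the three can be set apart from the others on these numbers.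

Compound 4 `CCN1CCN(CC(=O)Nc2ccc(-c3nc(-c4ccccc4)c(-c4ccccc4)n3C)cc2)CC1` is not yet measured. It differs from compound 3 in one place: methyl in place of hydrogen on a saturated chain carbon bound to an amine nitrogen in a ring. For the measured compounds named here, none of the measured steps touches this position; the two that changed the group on the saturated chain carbon bound to the carbonyl carbon swapped out a whole group rather than adding a single carbon, and even those stayed within the scatter. On the evidence at hand, the change to compound 4 is expected to give a step of a number 0.6 percentage points lower from compound 3 to compound 4 (within the scatter), that is, none beyond the scatter in this assay. Compound 4 is accordingly estimated at 28%, with a range from 18% to 38%.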

Compound 4, a percentage reported as activity, at one concentration (the size of the read-out at that concentration, not a potency): 16.4%
For compound 4 the middle estimate is 11.6 percentage points above the measured one; the measured number lies below the stated range.
By their numbers in this assay, from the lowest: compounds 4, 2, 1 and 3 (each within the scatter of the next, the first and the last beyond it).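

For the compounds shown here, the earlier compounds showed only that whole groups could be exchanged on the saturated chain carbon bound to a carbonyl carbon without a step beyond the scatter. Going by these compounds alone, at the new place, on a saturated chain carbon bound to an amine nitrogen in a ring, the single carbon that turns 4-methylpiperazin-1-yl into 4-ethylpiperazin-1-yl gives in this assay a step, a number 12.2 percentage points lower from compound 3 to compound 4 (beyond the scatter), that is larger than any among the earlier compounds, and the exchange of (5-chloro-1,3-benzoxazol-2-yl)sulfanyl for 4-ethylpiperazin-1-yl likewise gives a number 11.3 percentage points lower from compound 1 to compound 4 (beyond the scatter), whereas the exchange of (5-methyl-1,3-benzoxazol-2-yl)sulfanyl gives a number 8.2 percentage points lower from compound 2 to compound 4 (within the scatter), so compound 4 is set apart from compound 3 and compound 1 but not from compound 2. Nothing at hand bears on why one added carbon at this place should count for so much.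

Going by these compounds, whether a propyl group, a longer chain or a hydroxyethyl group at this place would stand with compound 3 or with compound 4 remains open. Also open, on these data alone, is whether a plain hydrogen on that amine nitrogen would fit either compound, since the ethyl result is a single step at a single concentration.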